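From chloroanilino to benzylamino on a shared core

The source may hold more compounds than are shown below. What is called first, only, known or untested is meant among the compounds shown, and "the series" means these compounds.

Among the compounds with values here, compound 2 `N#Cc1c(Nc2ccc(Cl)cc2)c(F)c2nc(N)nc(N)c2c1F` stands at the weaker end of the two numbers so far: in a functional assay on A549 cells (Homo sapiens) for cytotoxicity, read by MTT assay (on this read-out lower numbers stand for stronger inhibition and higher numbers for weaker inhibition), compound 2 gives 115 ug/mL, whereas compound 1 `N#Cc1c(Cl)c(Cl)c2nc(N)nc(N)c2c1Cl` in this assay gives 29.7 ug/mL, a gap reported as beyond the scatter. Compound 3 `N#Cc1c(NCc2ccccc2)c(F)c2nc(N)nc(N)c2c1F` differs from compound 2 by benzyl in place of 4-chlorophenyl on a nitrogen on an aromatic ring. Within the data shown here, no measured pair shows this change, so its size is unknown; the expected step is a 1.2-fold lower number from compound 2 to compound 3 (0.06 log units; within the scatter), which may well stay within the scatter. In this assay compound 3 is therefore estimated at 100 ug/mL, with a range from 40 ug/mL to 250 ug/mL.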

Compound 3, half-maximal inhibitory concentration: > 1000 ug/mL
Compound 3 gave a limit, no number (the forecaster's own chance of this, stated with the estimate: 15%); middle value at least 10-fold (1.00 log units) from the limit.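

In this assay, the swap of 4-chlorophenyl for benzyl on this nitrogen gives an at least 8.6-fold higher number from compound 2 to compound 3 (0.93 log units; beyond the scatter), so this position responds strongly to a change between two groups with the same count of heavy atoms. Compound 3 gives a limit, not a number, so the true size of the step stays unknown: the limit of > 1000 ug/mL in this assay, at which 1 of the 3 values shown sits.

The compounds shown leave open whether the loss of chlorine or the extra carbon on the nitrogen accounts for the step. A plain phenyl or a 4-chlorobenzyl group at this position would separate the two.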